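A few compounds are considered here, and "the series" means these few. Any claim that something is new, unique, unknown or untested is made for them only; others in the source may bear on it.

Of the compounds shown here, three sharing one core have been tested in a functional assay on MCF7 cells (Homo sapiens) for cytotoxicity, read by MTT assay, with a stated time of 24 h; on this read-out higher numbers stand for weaker inhibition and lower numbers for stronger inhibition. Compound 1 `Cc1c(CO)cc2n1[C@@H](c1ccccc1)SC2` gives 26400 nM in this assay. Compound 2 `Cc1c(COC(=O)NCc2ccccc2)cc2n1[C@@H](c1ccccc1)SC2` gives 8800 nM in this assay. Compound 3 `Cc1cc(CO)c2n1[C@@H](c1ccccc1)SC2` gives 110000 nM in this assay, the highest of the three numbers, and its gaps to compound 1 and to compound 2 both lie beyond the scatter, so compound 3 is the weakest inhibitor of the three. Compound 4 `Cc1c(CO)c(CO)c2n1[C@@H](c1ccccc1)SC2` awaits measurement and differs from compound 3 by hydroxymethyl in place of hydrogen on an aromatic carbon. Among the measured compounds shown here, no measured pair differs in a single place, so no step has been seen directly. Compound 1 also carries a hydroxymethyl group and in this assay gives 26400 nM. The expected step is a 3.7-fold lower number from compound 3 to compound 4 (0.56 log units; beyond the scatter), toward a lower number, beyond the scatter. Compound 4 is estimated at 30000 nM, within 10000 nM to 90000 nM.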

Compound 4, half-maximal inhibitory concentration: 12200 nM
For compound 4 the middle estimate is 2.5-fold (0.39 log units) above the measured one; low and high end bracket the measured number.
By their numbers in this assay, from the lowest: compounds 2 and 4 (each within the scatter of the next); then compound 1; then compound 3.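

In this assay, hydroxymethyl in place of hydrogen on an aromatic carbon gives a 9.0-fold lower number from compound 3 to compound 4 (0.96 log units; beyond the scatter), and the same change on the other aromatic carbon gives a 2.2-fold lower number from compound 1 to compound 4 (0.34 log units; beyond the scatter). Among the compounds shown here, these are the first direct steps, and both point toward stronger inhibition, so a second hydroxymethyl group is tolerated on either carbon. No evidence here accounts for either step. Going by these compounds, how an amine, a carboxylic acid or a longer chain on this aromatic carbon would compare remains open. The compounds shown also leave open whether the hydroxyl itself matters, which a methoxymethyl group could help to test.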